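The compounds below may be only part of what the source reports. "The series", "measured", "known", "first", "only" and "open" are said of these compounds alone.

Measured so far:
Compound 1, `COc1cc(NC(C)CCCNC(=O)NNC(=O)Nc2cc(C(F)(F)F)cc(C(F)(F)F)c2)c2ncccc2c1`: 2400 nM
Compound 2, `COc1cc(NC(C)CCCNC(=O)Nc2ccc(O)cc2)c2ncccc2c1`: 5200 nM
Compound 3, `COc1cc(NC(C)CCCNC(=O)NNC(=O)Nc2ccc(C(F)(F)F)cc2)c2ncccc2c1`: 100 nM

All three were tested in a functional assay on MCF7 cells (Homo sapiens) for inhibition, read by MTT assay, with a stated time of 72 h; on this read-out lower numbers stand for stronger inhibition and higher numbers for weaker inhibition. Among these three numbers compound 2 stands highest, which makes it the weakest inhibitor of the set. Its nearest neighbour is compound 1, whose number lies below it by more than the usual scatter, and compound 3 lies far lower still, well beyond the scatter. The not-yet-measured compound 4, `COc1cc(NC(C)CCCNC(=O)Nc2cccc(O)c2)c2ncccc2c1`, keeps every atom of compound 2 and differs only in how they are joined: 3-hydroxyphenyl in place of 4-hydroxyphenyl on an amide-type nitrogen. Among the measured compounds shown here, no measured pair here shows what this kind of rearrangement does to the read-out, so there is no measured step to lean on. A step within the usual scatter, in no particular direction, is expected, namely a step of a 1.0-fold lower number from compound 2 to compound 4 (0.02 log units; within the scatter). The value for compound 4 in this assay is therefore estimated at 5000 nM, with a range from 1500 nM to 16000 nM.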

Compound 4, half-maximal inhibitory concentration: 11000 nM
Beside the measured number, compound 4's estimate is 2.2-fold (0.34 log units) below it; low and high end bracket the measured number.
By their numbers in this assay, from the lowest: compound 3; then compound 1; then compound 2; then compound 4.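

In this assay, the swap of 4-hydroxyphenyl for 3-hydroxyphenyl on the amide-type nitrogen gives a 2.1-fold higher number from compound 2 to compound 4 (0.33 log units; beyond the scatter), a modest step but one beyond the usual scatter. Among the compounds shown here, this is the first sign that this position responds to a rearrangement alone: the group that enters has the same heavy atoms and the same counts of hydrogen-bond donors and acceptors as the one that leaves, yet inhibition is weaker. No supporting data explain the difference.

Still open, as far as these compounds go, is whether 2-hydroxyphenyl, or a methoxy group or an amine in place of the hydroxyl, would restore or further weaken inhibition. It is also unknown whether moving a substituent around the ring would matter to the same extent in compounds built like compound 3.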